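This account rests on a few compounds, and the source may have more. Where it says the series, first, only, none or still open, it means among the compounds named here.

Two compounds share one core, differing only in the group on a carbon with a double bond to nitrogen of the five-membered ring. Compound 1 `FC(F)(F)c1ccc(C2=NN(C(=S)Nc3ccccc3)C(c3ccc4c(c3)OCCO4)C2)cc1` carries a trifluoromethyl on that aromatic ring; in a functional assay on HT-29 cells (Homo sapiens) for antiproliferative activity, read by MTT assay, with a stated time of 48 h (a lower number here means a stronger inhibitor of growth, a higher number a weaker inhibitor of growth), compound 1 gives 97500 nM. Compound 2 `O=[N+]([O-])c1ccc(C2=NN(C(=S)Nc3ccccc3)C(c3ccc4c(c3)OCCO4)C2)cc1` carries a nitro there instead; in this assay compound 2 gives 153000 nM. For the measured compounds named here, the step of a 1.6-fold higher number from compound 1 to compound 2 (0.20 log units; within the scatter) is the only measured change so far, and compound 2 stands at the higher of the two numbers, with compound 1 its nearest neighbour, the two separated by less than the usual scatter.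

Compound 3 `Cc1ccc(C2=NN(C(=S)Nc3ccccc3)C(c3ccc4c(c3)OCCO4)C2)cc1C` has not yet been measured. Its change from compound 2 is 3,4-dimethylphenyl in place of 4-nitrophenyl on a carbon with a double bond to nitrogen, so a group with no hydrogen-bond acceptors replaces one with two. Going by the values given here, the one step that bears on this, from compound 1 to compound 2, was within the scatter, and it concerns a different pair of groups. On that basis no step beyond the scatter is expected, and the estimated step is a 1.3-fold lower number from compound 2 to compound 3 (0.11 log units; within the scatter). For compound 3 the expected value in this assay is 120000 nM, with a range from 40000 nM to 360000 nM.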

Compound 3, concentration for 50% growth inhibition: 133000 nM
Estimate against measurement, compound 3: 1.1-fold (0.04 log units) below; the range from low to high includes it.
By their numbers in this assay, from the lowest: compounds 1, 3 and 2 (each within the scatter of the next).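

In this assay, 3,4-dimethylphenyl in place of 4-nitrophenyl gives a small step (a 1.2-fold lower number from compound 2 to compound 3 (0.06 log units; within the scatter)), and 3,4-dimethylphenyl in place of 4-(trifluoromethyl)phenyl also gives a small step (a 1.4-fold higher number from compound 1 to compound 3 (0.13 log units; within the scatter)), so all three compounds now read within the scatter of one another. This adds a new kind of change at this position: 4-nitrophenyl has 2 hydrogen-bond acceptors and 3,4-dimethylphenyl has 0, and a ring with one group is replaced by a ring with two, yet neither difference gives a step that can be told from the scatter. No measurement is available to explain why these groups read alike.

From the compounds shown here alone, all three compounds carry a substituted phenyl ring at this position, so it remains open whether an amine, a carboxylic acid or a longer alkyl chain on that ring would give a step beyond the scatter. Going by these compounds, the 2,3-dihydro-1,4-benzodioxin-6-yl group stays the same throughout, so what a change at that place would do also remains open.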